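This account rests on a few compounds, and the source may have more. Where it says the series, first, only, none or still open, it means among the compounds named here.

Measured so far in a functional assay, read by spectrophotometry, with a stated time of 2 h, tested at 3 mg/mL; a higher number here means a stronger effect of the compound at the concentration tested, a lower number a weaker effect:
compound 1 `CC(C)[C@@H]1CC[C@@H](C)C[C@@]12N(C)C(=O)[C@@H]1[C@H]3C(=O)NC(=O)[C@H]3ON12` gives 72%
compound 2 `CC(C)[C@@H]1CC[C@@H](C)C[C@@]12N(C)C(=O)[C@@H]1[C@H]3C(=O)N(C)C(=O)[C@H]3ON12` gives 75.3%

Going by the values given here, compound 2 and compound 1 lie within the scatter of each other in this assay; the single measured step, a number 3.3 percentage points higher from compound 1 to compound 2 (within the scatter), is within the scatter, so neither compound stands apart. Compound 3 `CC(C)[C@@H]1CC[C@@H](C)C[C@@]12N(C)C(=O)[C@@H]1[C@H]3C(=O)N(c4ccccc4)C(=O)[C@H]3ON12` differs from compound 2 by phenyl in place of methyl on an amide-type nitrogen in a ring. Among the compounds with values here, the one step that bears on this change sits on the same nitrogen, a number 3.3 percentage points higher from compound 1 to compound 2 (within the scatter), and is within the scatter; no step with phenyl entering has been measured. Compound 3 is therefore expected to show no step beyond the scatter in this assay, estimated as a number 3.3 percentage points lower from compound 2 to compound 3 (within the scatter), with a wider range for the untested phenyl. The estimate for compound 3 is 72%, range 55% to 86%.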

Compound 3, a percentage reported as activity, at one concentration (the size of the read-out at that concentration, not a potency): 73.5%
Beside the measured number, compound 3's estimate is 1.5 percentage points below it; low and high end bracket the measured number.
By their numbers in this assay, from the lowest: compounds 1, 3 and 2 (each within the scatter of the next).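

Against methyl and against hydrogen, phenyl on an amide-type nitrogen in a ring gives in this assay the steps of a number 1.8 percentage points lower from compound 2 to compound 3 (within the scatter) and a number 1.5 percentage points higher from compound 1 to compound 3 (within the scatter) at this position. Hydrogen, methyl and phenyl on this nitrogen therefore all lie within the scatter of each other, even with an aromatic ring of carbon only entering here. Nothing at hand gives a reason for this flat reading. Open, on these data alone, is whether a longer chain, an amine or a carboxylic acid on this nitrogen would give a step beyond the scatter. Also open, as far as these compounds go, is whether a phenyl carrying a further group would do so.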